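This account rests on a few compounds, and the source may have more. Where it says the series, first, only, none or still open, it means among the compounds named here.

Working notes on the series. In a functional assay on cells for antagonist activity at prostaglandin E2 receptor EP1 subtype (Rattus norvegicus), read by fluorescence and calcium flux, with a stated time of 60 s (a lower number here means a stronger inhibitor, a higher number a weaker inhibitor), compound 1 `O=C(O)c1cccc(Cc2c(-c3ccccc3)nn3cc(C4CC4)ccc23)n1` gives 190 nM. Compound 2 `O=C(O)c1cccc(Cc2c(-c3ccc(Cl)cc3)nn3cc(Cl)ccc23)n1` gives 1100 nM in this assay, and compound 3 `O=C(O)c1cccc(Cc2c(-c3cccs3)nn3cc(Cl)ccc23)n1` gives 1100 nM. Compound 3 thus stands level with compound 2 within the scatter, the two together giving the highest numbers of the three, while compound 1 sits lower by a margin beyond the scatter; compound 1 differs from compound 3 in two places, so only the two values can be set side by side. For the measured compounds named here, the one single-point step measured so far, no change at the digits printed from compound 2 to compound 3 (within the scatter), shows that exchange of one aromatic group for another on that aromatic carbon of the core left the number where it was.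

Compound 4 `O=C(O)c1cccc(Cc2c(N3CCCCCC3)nn3cc(Cl)ccc23)n1` carries the change (azepan-1-yl in place of thiophen-2-yl on an aromatic carbon). Here the group that leaves is a five-membered aromatic ring and the group that enters is a seven-membered non-aromatic ring, so the step from compound 2 to compound 3 bears on it only in part: it says one aromatic group may replace another at this place without effect, but nothing is measured for a non-aromatic ring there. In this assay the step of a 1.5-fold higher number from compound 3 to compound 4 (0.16 log units; within the scatter) is expected to be modest, leaning towards a higher number, with wide uncertainty. Compound 4 is estimated at 1600 nM, with a range from 400 nM to 6500 nM.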

Compound 4, half-maximal inhibitory concentration: 1400 nM
Estimate against measurement, compound 4: 1.1-fold (0.06 log units) above; low and high end bracket the measured number.
By their numbers in this assay, from the lowest: compound 1; then compounds 2, 3 and 4 (each within the scatter of the next).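

In this assay, azepan-1-yl on this aromatic carbon gives a 1.3-fold higher number from compound 3 to compound 4 (0.10 log units; within the scatter), and a 1.3-fold higher number from compound 2 to compound 4 (0.10 log units; within the scatter), so the replacement of an aromatic group by a seven-membered non-aromatic ring leaves the number within the scatter from either starting point. With the chloro group on the core held constant, 4-chlorophenyl, thiophen-2-yl and azepan-1-yl all give numbers within the scatter of one another, which extends the earlier aromatic-for-aromatic result: among these three compounds, an aromatic ring at this place is not needed to keep the number at this level. No supporting data are at hand to explain why the number holds across these groups.

From the compounds shown here alone, compound 1 gives 190 nM, but it differs from each of the other compounds in two places, so the series does not separate the contribution of its phenyl group from that of its cyclopropyl group, and whether azepan-1-yl would hold the number on that core remains open. Also open, going by these compounds, is whether the same insensitivity extends to an open-chain amine such as dimethylamino, or to a small group such as methyl, on this carbon.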